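Nitro-aryl sulfonamide series: step from compound 3 to compound 4

The compounds below may be only part of what the source reports. "The series", "measured", "known", "first", "only" and "open" are said of these compounds alone.

Measured so far:
Compound 1, `Cc1ccc([N+](=O)[O-])cc1C(=O)N1CCC(c2cnn3ccc(Br)cc23)CC1`: in an assay on isolated protein for inhibition of phosphatidylinositol 4,5-bisphosphate 3-kinase catalytic subunit beta isoform (Homo sapiens) (a lower number here means a stronger inhibitor, a higher number a weaker inhibitor), compound 1 gives > 1000 nM, which is a limit of the assay and not a number.
Compound 2, `Cc1ccc([N+](=O)[O-])cc1S(=O)(=O)N[C@@H]1CCN(Cc2cnn3ccc(C#N)cc23)C1`: in this assay compound 2 gives > 1000 nM, again a limit.
Compound 3, `Cc1ccc([N+](=O)[O-])cc1S(=O)(=O)N[C@H]1CCCN(Cc2cnn3ccc(C#N)cc23)C1`: in this assay compound 3 gives > 1000 nM, also a limit.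

Compound 3 therefore stands nowhere in particular: only a limit is known for it, and the two other values shown are limits as well, so all three sit at the same edge of the assay (the limit of > 1000 nM in this assay, at which 3 of the 3 values shown sit). Going by the values given here, no pair of measured compounds differs in a single place, so no measured step size is available to lean on.

The next compound is compound 4, `Cc1ccc([N+](=O)[O-])cc1S(=O)(=O)N[C@@H]1CCCN(Cc2cnn3ccc(C#N)cc23)C1`. (the two compounds have the same atoms and bonds and differ only in configuration as drawn: 1 of 1 stereo elements differ; a stereocentre at a saturated ring carbon is drawn S in compound 3 and R in compound 4); the two compounds have the same atoms and bonds and differ only in configuration as drawn. Among the compounds with values here, nothing among the measured compounds shows what a change of configuration does, and compound 3 gives no number to move from (the limit of > 1000 nM in this assay, at which 3 of the 3 values shown sit). The estimate implies a step that the limit leaves unreadable from compound 3 to compound 4, expected to be none beyond the scatter. For compound 4 the expected value in this assay is 3000 nM, in the range 800 nM to 15000 nM, most likely reported again only as a limit.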

Compound 4, half-maximal inhibitory concentration: > 1000 nM
Compound 4 gave a limit, no number; the forecaster's own chance of this, stated with the estimate: 80%; the middle value is on the limit's open side.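

No step can be read from compound 3 to compound 4, a pair differing only in the configuration at a saturated ring carbon, since neither gives a number: the limit of > 1000 nM in this assay, at which 4 of the 4 values shown sit.

The compounds shown leave open whether that configuration matters at all in this series, and which structural change would bring a value inside the range of the assay.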